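This account rests on a few compounds, and the source may have more. Where it says the series, first, only, none or still open, it means among the compounds named here.

Measured compounds and their values:

Compound 1, `CC1CCN(C2CCN(S(=O)(=O)c3cccc(Br)c3)CC2)CC1`, gives 1.2 nM in a functional assay on HT-29 cells (Homo sapiens) for antiproliferative activity, read by CellTiter-Glo, with a stated time of 72 h; a lower number here means a stronger inhibitor, a higher number a weaker inhibitor.
Compound 2, `COc1ccc(Br)cc1S(=O)(=O)N1CCC(N2CCC(C)CC2)CC1`, gives 2 nM in this assay.
Compound 3, `Cc1cc(C)c(S(=O)(=O)N2CCC(N3CCC(C(C)C)CC3)CC2)c(C)c1`, gives 0.2 nM in this assay.

Among the three numbers, compound 1 stands second highest: its nearest neighbour is compound 2, reached by a 1.7-fold higher number from compound 1 to compound 2 (0.22 log units; within the scatter), a step within the scatter, while compound 3 lies furthest from it, with a lower number, a gap beyond the scatter. Among the compounds with values here, compound 3 differs from compound 1 in two places at once, so no single step connects them.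

The unmeasured compound 4, `CC1CCN(C2CCN(S(=O)(=O)c3ccc(Cl)c(Cl)c3)CC2)CC1`, differs from compound 1 as follows:

3,4-dichlorophenyl in place of 3-bromophenyl on a sulfonyl sulfur

Within the data shown here, only one measured step touches the aryl group on the sulfonyl sulfur: the methoxy addition from compound 1 to compound 2, which stayed within the scatter. Among the measured compounds shown here, no measured step swaps one halogen pattern for another on that ring. With that single step as guide, a change within the scatter is expected for compound 4, the expected step being a 1.3-fold lower number from compound 1 to compound 4 (0.12 log units; within the scatter). Compound 4 is therefore estimated at 0.9 nM, with a range from 0.3 nM to 3 nM.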

Compound 4, half-maximal inhibitory concentration: 2.2 nM
Compound 4: middle estimate off by 2.4-fold (0.39 log units), on the low side; the range from low to high includes it.
By their numbers in this assay, from the lowest: compound 3; then compounds 1, 2 and 4 (each within the scatter of the next).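

In this assay, 3,4-dichlorophenyl in place of 3-bromophenyl on a sulfonyl sulfur gives a 1.8-fold higher number from compound 1 to compound 4 (0.26 log units; within the scatter), which shows that this position accepts a change of halogen and of halogen pattern with no shift that can be told from the scatter. The earlier step, a 1.7-fold higher number from compound 1 to compound 2 (0.22 log units; within the scatter), added a methoxy group to the brominated ring and kept the bromine, whereas this step replaces the bromine altogether, so among compounds 1, 2 and 4 two different changes to this aryl group both stay within the scatter. No measurement is available that would explain this result or connect it to any property of the two groups.

From the compounds shown here alone, whether this aryl group would carry a carboxylic acid, an amine or a longer chain as readily as it carries these halogens remains open, as does the result for a plain phenyl ring without any substituent. Compound 3 differs from compound 1 in two places at once, so the compounds shown cannot say how much of its gap comes from the aryl group and how much from the other place.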